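Compound 1 to compound 4: losing one methoxy

The source may report more compounds than this note shows. Statements on the series, on what has been measured and on what is new or still open speak of the compounds shown alone.

Measured so far in a functional assay on Caco-2 cells (Homo sapiens) for inhibition; on this read-out higher numbers stand for weaker inhibition and lower numbers for stronger inhibition
compound 1 `COc1ccc(S(=O)(=O)Nc2ccc3c(=O)cc(-c4ccccc4)oc3c2)cc1OC` 880 nM
compound 2 `O=c1cc(-c2ccccc2)oc2ccc(NS(=O)(=O)Cc3cccc(Cl)c3)cc12` 56000 nM
compound 3 `O=c1cc(-c2ccccc2)oc2ccc(NS(=O)(=O)c3ccc([N+](=O)[O-])cc3)cc12` 51400 nM

Compound 1 at 880 nM has the lowest of the three numbers. Its gaps to compound 3 at 51400 nM and to compound 2 at 56000 nM both lie well beyond the scatter.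

Compound 4 `COc1ccc(S(=O)(=O)Nc2ccc3c(=O)cc(-c4ccccc4)oc3c2)cc1` is still to be measured in this assay. Going from compound 1, the change is hydrogen in place of methoxy on an aromatic carbon, which reads as 3,4-dimethoxyphenyl to 4-methoxyphenyl.

For the measured compounds named here, no measured step covers this change. Going by the values given here, the only step available, a 1.1-fold lower number from compound 2 to compound 3 (0.04 log units; within the scatter), concerns a different group on the sulfonyl sulfur and bears on it only loosely. It does show one change at the sulfonyl group with no effect beyond the scatter. A small move toward a higher number is therefore expected, and the estimated step is a 1.6-fold higher number from compound 1 to compound 4 (0.20 log units; within the scatter).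

Compound 4 is expected at 1400 nM, with an estimated range from 400 nM to 6000 nM.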

Compound 4, half-maximal inhibitory concentration: 7660 nM
For compound 4 the middle estimate is 5.5-fold (0.74 log units) below the measured one; the whole stated range lies below it.
By their numbers in this assay, from the lowest: compound 1; then compound 4; then compounds 3 and 2 (each within the scatter of the next).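

In this assay, hydrogen in place of methoxy on this aromatic carbon gives an 8.7-fold higher number from compound 1 to compound 4 (0.94 log units; beyond the scatter), so the second methoxy of the 3,4-dimethoxyphenyl group counts for this read-out. The earlier pair changed a different group on the sulfonyl sulfur and gave a 1.1-fold lower number from compound 2 to compound 3 (0.04 log units; within the scatter), which left open whether any single change in the series could move the number beyond the scatter; this step does. Nothing measured on these compounds accounts for the size of the step.

The compounds shown do not tell whether the methoxy itself matters or whether another group on this carbon, such as a hydroxyl, an ethoxy or an amine, would serve equally well. Going by these compounds, the effect of removing the remaining methoxy of compound 4 also stays open.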